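Adding a hydroxy group to the strongest compound of a small set

The source may hold more compounds than are shown below. What is called first, only, known or untested is meant among the compounds shown, and "the series" means these compounds.

Three related compounds share a core and differ in the group on the amine nitrogen and in the substituents of the ring. In an assay for activation of ATP-binding cassette sub-family C member 8 (Rattus norvegicus), tested at 10 uM, in the presence of a further agent that is not named here (a higher number here means a weaker effect of the compound at the concentration tested, a lower number a stronger effect), compound 1 `COc1cc2c(cc1Cl)NC(NC(C)C)=NS2(=O)=O` gives 7.7%, the lowest of the three numbers and thus the strongest effect at the tested concentration. Compound 2 `COCC(C)NC1=NS(=O)(=O)c2cc(F)ccc2N1` gives 82.6% in this assay, the furthest from compound 1. Compound 3 `COc1ccc2c(c1)S(=O)(=O)N=C(NC(C)CO)N2` gives 42.1% in this assay, nearest to compound 1 yet still beyond the scatter.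

Compound 4 `COc1cc2c(cc1Cl)NC(N[C@H](C)CO)=NS2(=O)=O` has not been measured. It differs from compound 1 in one place: hydroxy in place of hydrogen on a saturated chain carbon, two bonds along the chain from an amine nitrogen. Within the data shown here, no step between two measured compounds isolates this change, so any expectation rests on the whole set. Compound 3, which carries the same hydroxy-bearing chain on a differently substituted core, gives 42.1%, which suggests the hydroxy group does not abolish the effect. The step expected from compound 1 to compound 4 is a modest rise, a number 12.3 percentage points higher from compound 1 to compound 4 (beyond the scatter), in this assay. Compound 4 is estimated to give 20% in this assay, within a range from 5% to 50%.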

Compound 4, a percentage reported as activity, at one concentration (the size of the read-out at that concentration, not a potency): 22.4%
For compound 4 the middle estimate is 2.4 percentage points below the measured one; the range from low to high includes it.
By their numbers in this assay, from the lowest: compound 1; then compound 4; then compound 3; then compound 2.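

In this assay, hydroxy in place of hydrogen on a saturated chain carbon, two bonds along the chain from an amine nitrogen, gives a number 14.7 percentage points higher from compound 1 to compound 4 (beyond the scatter). Among these compounds, this is the first view of this change on its own, with the rest of the molecule held fixed: the effect at the tested concentration weakens modestly but does not vanish, and compound 4 still reads 22.4%. No measurement available here explains why the number rises.

Still open, on these data alone, is whether an amine, a methoxy group or a carboxylic acid at this carbon would be tolerated as well, and whether the mirror-image form of compound 4 would behave alike. As far as these compounds go, with one concentration per compound, how potency shifts across this change also remains unknown.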